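The source may report more compounds than this note shows. Statements on the series, on what has been measured and on what is new or still open speak of the compounds shown alone.

Compound 3 `CC(=O)NC[C@@H]1C[C@H]1c1cccc2nc(CCCCc3ccccc3)oc12` is the strongest of the three compounds measured in an assay on NIH3T3 cells with melatonin receptor type 1A (Homo sapiens) as the target; a lower number here means a stronger inhibitor, a higher number a weaker inhibitor: compound 3 gives 0.05 nM, whereas compound 1 `CCC1Nc2cccc([C@@H]3C[C@H]3CNC(=O)C(C)C)c2O1` gives 0.2 nM and compound 2 `CC(C)C(=O)NC[C@@H]1C[C@H]1c1cccc2c1OC(C(C)C)N2` gives 1.3 nM. Compound 4 `O=C(NC[C@@H]1C[C@H]1c1cccc2nc(CCCCc3ccccc3)oc12)C1CC1` has not been measured; it differs from compound 3 by cyclopropyl in place of methyl on a carbonyl carbon. Within the data shown here, the only step measured so far, a 6.5-fold higher number from compound 1 to compound 2 (0.81 log units; beyond the scatter), concerns the ring carbon of the shared core, not the carbonyl carbon, so it bears on the present change only loosely; it shows that adding carbon at one place of this series cost potency modestly. Among the measured compounds shown here, no step at the amide carbonyl has been measured, so the expectation rests on the small size of the change and on the weak analogy to that single step. A small change is therefore expected in this assay, a 1.6-fold higher number from compound 3 to compound 4 (0.20 log units; within the scatter), or none beyond the scatter. Compound 4 is estimated to give 0.08 nM in this assay, within a range from 0.03 nM to 0.3 nM.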

Compound 4, inhibition constant: 0.05 nM
Beside the measured number, compound 4's estimate is 1.6-fold (0.20 log units) above it; the measured number falls inside the stated range.
By their numbers in this assay, from the lowest: compounds 3 and 4 (each within the scatter of the next); then compound 1; then compound 2.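

In this assay, among these compounds, the step of no change at the digits printed from compound 3 to compound 4 (within the scatter) gives the first reading at the carbonyl carbon: cyclopropyl, with 3 heavy atoms and one three-membered ring, stands in place of methyl, with 1 heavy atom, and the number does not move beyond the scatter. Among the compounds shown here, the only earlier step of a 6.5-fold higher number from compound 1 to compound 2 (0.81 log units; beyond the scatter) lay at a saturated chain carbon, so added carbon cost potency at that place, whereas this pair shows no such cost at the carbonyl carbon. Nothing shown explains why this change leaves the number in place. Still open, as far as these compounds go, is whether a longer chain such as propyl, or an amine, would be tolerated equally on this carbonyl carbon. Also open, from the compounds shown here alone, is whether cyclopropyl in place of methyl would read the same on a core carrying a different substituent from the 4-phenylbutyl chain of compound 3.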